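Phenyl to pyridin-2-yl on the piperazine amide series

The compounds below may be only part of what the source reports. "The series", "measured", "known", "first", "only" and "open" are said of these compounds alone.

compound 1 `COc1ccc(C[C@@H](O)/C=C/C=C/C(=O)N2CCCCC2)cc1OC` - 39500 nM
compound 2 `COc1ccc(C[C@@H](O)/C=C/C=C/C(=O)N2CCN(c3ccccc3)CC2)cc1OC` - 12000 nM

In a functional assay on MCF7 cells (Homo sapiens) for antiproliferative activity, read by sulforhodamine B assay, with a stated time of 48 h (on this read-out lower numbers stand for stronger inhibition and higher numbers for weaker inhibition), compound 2 gives the lower of the two numbers at 12000 nM. The nearest number belongs to compound 1 at 39500 nM, and that gap lies beyond the usual scatter.

The next entry is compound 3 `COc1ccc(C[C@@H](O)/C=C/C=C/C(=O)N2CCN(c3ccccn3)CC2)cc1OC`, with pyridin-2-yl in place of phenyl on an amine nitrogen in a ring. Going by the values given here, no measured pair differs in one place only, so the data offer no direct precedent for this change. In this assay no step beyond the scatter is expected, and no direction is favoured. The expected change is no change at the digits printed from compound 2 to compound 3 (within the scatter). For compound 3 the estimated value is 12000 nM, with an expected range of 5000 nM to 28000 nM.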

Compound 3, half-maximal inhibitory concentration: 23600 nM
Estimate against measurement, compound 3: 2.0-fold (0.29 log units) below; measured number inside the range.
By their numbers in this assay, from the lowest: compounds 2, 3 and 1 (each within the scatter of the next, the first and the last beyond it).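

In this assay, going by these compounds alone, the step with pyridin-2-yl in place of phenyl on an amine nitrogen in a ring is a 2.0-fold higher number from compound 2 to compound 3 (0.29 log units; within the scatter) and is the first single-place comparison. At this position, an aromatic ring nitrogen and the 1 hydrogen-bond acceptor counted with it therefore leave the number within the scatter, so this one change gives no readable effect on the antiproliferative read-out. No evidence on hand accounts for the size of this step.

From the compounds shown here alone, whether the nitrogen's place in the ring matters stays open, and pyridin-3-yl, pyridin-4-yl or pyrimidin-2-yl at the same place would test that. A benzyl group or a small alkyl chain on the same amine nitrogen would show whether anything at this position can move the number beyond the scatter.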